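Trifluoromethyl for methyl on a weak Rho-kinase amide

The compounds below may be only part of what the source reports. "The series", "measured", "known", "first", "only" and "open" are said of these compounds alone.

Measured so far:
compound 1, `CN(C)c1ccc(C(=O)Nc2ccc(NC(=O)COc3ccc4c(=O)ccoc4c3)cc2)cc1`, in an assay on isolated protein for inhibition of Rho-associated protein kinase 1 (Homo sapiens), read by scintillation counting, radiometric assay and 33P incorporation, with a stated time of 40 min, in the presence of a further agent that is not named here (on this read-out lower numbers stand for stronger inhibition and higher numbers for weaker inhibition), compound 1 gives 1050 nM.
compound 2, `Cc1cc(NC(=O)COc2ccc3c(=O)ccoc3c2)ccc1NC(=O)c1ccc(N(C)C)cc1`, in this assay compound 2 gives only a limit of the assay, > 10000 nM.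

Compound 2 thus stands at the weak end of what has been measured: its value is not a number but the assay limit, (the limit of > 10000 nM in this assay, at which 1 of the 2 values shown sits). Among the measured compounds shown here, the one measured step that reaches it, an at least 9.5-fold higher number from compound 1 to compound 2 (0.97 log units; beyond the scatter), already shows that placing a methyl on that aromatic carbon costs potency, though only the lower bound of the loss is known.

Compound 3, `CN(C)c1ccc(C(=O)Nc2ccc(NC(=O)COc3ccc4c(=O)ccoc4c3)cc2C(F)(F)F)cc1`, changes the same position again: trifluoromethyl in place of methyl on an aromatic carbon. For the measured compounds named here, no measured pair shows a trifluoromethyl, so the only guidance is the step from compound 1 to compound 2, which points downward. Since compound 2 is already at the limit, a further downward step cannot be seen as a number; the expectation is that compound 3 stays at or beyond that limit. The estimated step is a step that the limit leaves unreadable from compound 2 to compound 3, meaning essentially no visible change. Compound 3 is therefore expected to give about 15000 nM, within a range from 4000 nM to 60000 nM.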

Compound 3, half-maximal inhibitory concentration: > 10000 nM
Compound 3: no number, only a limit (the forecaster's own chance of this, stated with the estimate: 70%); the middle value lies beyond the limit too.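

Replacing hydrogen with trifluoromethyl on this aromatic carbon gives an at least 9.5-fold higher number from compound 1 to compound 3 (0.97 log units; beyond the scatter) in this assay, so the loss seen earlier with methyl, an at least 9.5-fold higher number from compound 1 to compound 2 (0.97 log units; beyond the scatter), is not unique to methyl: two different groups on the same carbon, one with a single heavy atom and one with four, both leave compound 1's measurable potency behind. In this assay compound 3 gives > 10000 nM, which is a limit of the assay and not a number. The step between the methyl and trifluoromethyl compounds cannot be read, so the two groups cannot be ranked against each other, and the data show only that both fall past the measurable range: the limit of > 10000 nM in this assay, at which 2 of the 3 values shown sit.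

How far past the limit compound 2 and compound 3 lie remains unknown, so either group could cost only a little more than the minimum shown or a great deal more. Only hydrogen, methyl and trifluoromethyl appear on this carbon, which leaves open whether a single fluorine atom, a hydroxyl group or an amine there would keep the activity of compound 1.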